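The source may report more compounds than this note shows. Statements on the series, on what has been measured and on what is new or still open speak of the compounds shown alone.

Values in a functional assay on A549 cells (Homo sapiens) for antiproliferative activity, read by MTT assay, with a stated time of 72 h; a higher number here means a weaker inhibitor, a lower number a stronger inhibitor:
- Compound 1 `COc1cc(-n2cnc3ccc(-c4ccccc4Cl)cc32)cc(OC)c1OC`: > 10000 nM ( a limit of the assay, not a number )
- Compound 2 `COc1cc(-n2cnc3ccc(-c4cc(F)ccc4F)cc32)cc(OC)c1OC`: 7940 nM
- Compound 3 `COc1cc(-n2cnc3ccc(-c4cccc(O)c4)cc32)cc(OC)c1OC`: 250 nM

Compound 3 has the lowest number of the three, which makes it the strongest inhibitor here. Its nearest neighbour is compound 2 at 7940 nM.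

Compound 4 `COc1cc(-n2cnc3ccc(-c4ccc(Cl)cc4)cc32)cc(OC)c1OC` keeps the shared core and changes one group, with 4-chlorophenyl in place of 3-hydroxyphenyl on an aromatic carbon.

Within the data shown here, two measured steps bear on this change, and both run the opposite way, from a halogen-bearing phenyl to 3-hydroxyphenyl. They are a 32-fold lower number from compound 2 to compound 3 (1.50 log units; beyond the scatter) and an at least 40-fold lower number from compound 1 to compound 3 (1.60 log units; beyond the scatter), and both are large. The remaining step, an at least 1.2-fold lower number from compound 1 to compound 2 (0.10 log units; that floor lies within the scatter), does not separate the two halogen-bearing rings beyond the scatter. Among the measured compounds shown here, no measured compound carries 4-chlorophenyl itself, so this reading rests on only two halogen-bearing neighbours.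

Giving up 3-hydroxyphenyl is therefore expected to cost a similarly large step towards a higher number in this assay. The estimated step is a 32-fold higher number from compound 3 to compound 4 (1.51 log units; beyond the scatter). For compound 4 the expected value is 8000 nM, with an estimated range of 2000 nM to 20000 nM.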

Compound 4, half-maximal inhibitory concentration: > 10000 nM
Compound 4: a limit, no number; the forecaster's own chance of this, stated with the estimate: 40%; middle value at least 1.2-fold (0.09 log units) away from the limit.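

In this assay compound 4 gives > 10000 nM and that is a limit of the assay, not a number. The change from 3-hydroxyphenyl to 4-chlorophenyl is an at least 40-fold higher number from compound 3 to compound 4 (1.60 log units; beyond the scatter) and it adds a third halogen-bearing ring, after those of compound 1 and compound 2, that stays far from compound 3, so among these four compounds only 3-hydroxyphenyl gives a low number at this position. The step of an at least 1.2-fold higher number from compound 2 to compound 4 (0.10 log units; that floor lies within the scatter) does not set 2,5-difluorophenyl and 4-chlorophenyl apart, and the step between compound 1 and compound 4 cannot be read: the limit of > 10000 nM in this assay, at which 2 of the 4 values shown sit.

Among these compounds, what remains open is whether the gain belongs to the hydroxyl group itself, to its place on the ring, or simply to the absence of a halogen, since compound 3 is the only compound here with a low number. An unsubstituted phenyl, 4-hydroxyphenyl, 3-methoxyphenyl or 3-aminophenyl at this position would help to separate these readings, and the rings now sitting at the limit would need a wider range of concentrations before they could be ranked.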